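Replacing Methyl by Pyridin-4-yl on the Shared Core

This account rests on a few compounds, and the source may have more. Where it says the series, first, only, none or still open, it means among the compounds named here.

Three measured compounds share one core with a phenyl-capped chain attached through a carbonyl, and differ only in the group on one carbon of the ring. In an assay on HEK-293T cells for inhibition of diacylglycerol lipase-alpha (Homo sapiens), read by colorimetric assay (on this read-out lower numbers stand for stronger inhibition and higher numbers for weaker inhibition), compound 1 `O=Cc1coc(C(=O)CCCCCCc2ccccc2)n1` gives 1510 nM. Compound 2 `O=C(CCCCCCc1ccccc1)c1nc(Br)co1` reaches only a limit of this assay, > 10000 nM. Compound 3 `Cc1coc(C(=O)CCCCCCc2ccccc2)n1` likewise reports only a limit, > 10000 nM. Compound 3 therefore stands at the limit of > 10000 nM in this assay, at which 2 of the 3 values shown sit, and no number places it against compound 2. The steps read an at least 6.6-fold higher number from compound 1 to compound 2 (0.82 log units; beyond the scatter) and an at least 6.6-fold higher number from compound 1 to compound 3 (0.82 log units; beyond the scatter), while a step that the two limits leave unreadable from compound 2 to compound 3.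

Compound 4 `O=C(CCCCCCc1ccccc1)c1nc(-c2ccncc2)co1` carries the change (pyridin-4-yl in place of methyl on an aromatic carbon). For the measured compounds named here, both readable steps touch this same carbon and show that bromo or methyl in place of formyl weakens inhibition, but neither involves pyridin-4-yl, so they set no direction for this step. The author expects an at least 1.2-fold lower number from compound 3 to compound 4 (0.09 log units; that floor lies within the scatter), with compound 4 likely near the limit again. Compound 4 is estimated at 8000 nM, within 1500 nM to 30000 nM.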

Compound 4, half-maximal inhibitory concentration: > 10000 nM
Compound 4 ended at the assay's limit; the forecaster's own chance of this, stated with the estimate: 55%; at least 1.2-fold (0.09 log units) between middle value and limit.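

With compound 4 also at a limit in this assay, pyridin-4-yl joins bromo and methyl on this aromatic carbon, so a group with one six-membered aromatic ring and a hydrogen-bond acceptor does not bring inhibition into a readable range. Set against formyl, the change gives an at least 6.6-fold higher number from compound 1 to compound 4 (0.82 log units; beyond the scatter), and formyl remains the only group on this carbon with a number. The steps among compound 2, compound 3 and compound 4 cannot be read, and the set now sits mostly at one edge of the assay: the limit of > 10000 nM in this assay, at which 3 of the 4 values shown sit.

On these data alone, how far compound 2, compound 3 and compound 4 lie past that limit, and whether they differ at all, stays open. Also open, as far as these compounds go, is whether another group on this carbon, such as a carboxylic acid, a nitrile or an amine, would give a readable number as formyl does.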